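A few compounds are considered here, and "the series" means these few. Any claim that something is new, unique, unknown or untested is made for them only; others in the source may bear on it.

Going by the values given here, compound 3 `COc1ccc(CNCCCNS(=O)(=O)c2cc(C(F)(F)F)cc(C(F)(F)F)c2)cc1` is one of three compounds measured in a functional assay on BXPC-3 cells (Homo sapiens) for inhibition, read by MTT assay, with a stated time of 72 h; a higher number here means a weaker inhibitor of growth, a lower number a stronger inhibitor of growth. Compound 3 gives 1300 nM, the second highest of the three numbers. Compound 1 `O=S(=O)(NCCCNCC1COc2ccccc2O1)c1cc(C(F)(F)F)cc(C(F)(F)F)c1` gives 1200 nM, and the step of a 1.1-fold higher number from compound 1 to compound 3 (0.03 log units; within the scatter) lies within the scatter. Compound 2 `O=S(=O)(NCCCNCc1ccccc1)c1cc(C(F)(F)F)cc(C(F)(F)F)c1` gives 13000 nM, and the step of a 10-fold lower number from compound 2 to compound 3 (1.00 log units; beyond the scatter) lies beyond the scatter. Compound 4 `COc1ccccc1CNCCCNS(=O)(=O)c1cc(C(F)(F)F)cc(C(F)(F)F)c1` has not yet been measured. The change from compound 3 to compound 4 is 2-methoxyphenyl in place of 4-methoxyphenyl on a saturated chain carbon bound to an amine nitrogen. Among the compounds with values here, two measured steps bear on it: a 10-fold lower number from compound 2 to compound 3 (1.00 log units; beyond the scatter) shows that methoxy in place of hydrogen on the aromatic carbon matters a good deal, while a 1.1-fold higher number from compound 1 to compound 3 (0.03 log units; within the scatter) shows that a quite different group at the same place gives a number within the scatter of compound 3. Within the data shown here, no measured pair compares 4-methoxyphenyl with 2-methoxyphenyl, so that particular move is untested. With the methoxy group kept and only its place on the ring changed, and with compound 3 at 1300 nM, a step of no more than modest size is expected, in either direction. Compound 4 is expected at 1800 nM, within a range of 600 nM to 6000 nM. The expected step of a 1.4-fold higher number from compound 3 to compound 4 (0.14 log units; within the scatter) is small.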

Compound 4, concentration for 50% growth inhibition: 1700 nM
Compound 4: the middle estimate sits 1.1-fold (0.02 log units) above what was measured; low and high end bracket the measured number.
By their numbers in this assay, from the lowest: compounds 1, 3 and 4 (each within the scatter of the next); then compound 2.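

In this assay, moving the methoxy group from 4-methoxyphenyl to 2-methoxyphenyl gives a 1.3-fold higher number from compound 3 to compound 4 (0.12 log units; within the scatter), so for this pair the place of the methoxy group on the ring makes no difference that can be told from the scatter. The advantage over plain phenyl therefore holds for the 2-methoxyphenyl group as well as for the 4-methoxyphenyl group, with a 7.6-fold lower number from compound 2 to compound 4 (0.88 log units; beyond the scatter). The 2-methoxyphenyl group also stays level with the 2,3-dihydro-1,4-benzodioxin-2-yl group, with a 1.4-fold higher number from compound 1 to compound 4 (0.15 log units; within the scatter).

Nothing beyond these growth numbers is available to explain what the methoxy group does at this position. Going by these compounds, it remains open whether methoxy itself is needed, or whether a hydroxy group, a chlorine or a dimethylamino group on the same ring would give a similarly low number.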